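Swapping the amine substituent at the benzylamine end of compound 3

A few compounds are considered here, and "the series" means these few. Any claim that something is new, unique, unknown or untested is made for them only; others in the source may bear on it.

Three sulfonamides sharing one core have been tested in a toxicity assay on MCF-10A cells (Homo sapiens) for inhibition, read by MTT assay, with a stated time of 72 h; a lower number here means a stronger inhibitor of growth, a higher number a weaker inhibitor of growth. Compound 1 `O=S(=O)(NCCCNCc1ccccc1Cl)c1cc(C(F)(F)F)cc(C(F)(F)F)c1` gives 11000 nM. Compound 2 `CC(C)(C)c1ccc(CNCCCNS(=O)(=O)c2cc(C(F)(F)F)cc(C(F)(F)F)c2)cc1` gives 3200 nM, a change of a 3.4-fold lower number from compound 1 to compound 2 (0.54 log units; beyond the scatter). Compound 3 `CN(CCCNS(=O)(=O)c1cc(C(F)(F)F)cc(C(F)(F)F)c1)Cc1ccccc1` gives 26000 nM, the highest of the three numbers, reached by a step of a 2.4-fold higher number from compound 1 to compound 3 (0.37 log units; beyond the scatter). Compound 4 `COc1ccccc1CNCCCNS(=O)(=O)c1cc(C(F)(F)F)cc(C(F)(F)F)c1` has not yet been measured. It differs from compound 3 by (2-methoxybenzyl)amino in place of benzyl(methyl)amino on a saturated chain carbon, three bonds along the chain from a sulfonamide nitrogen. This step undoes the methylation of the amine and returns to a benzyl group carrying a single substituent, much as in compound 1, whose own step to compound 3 was modest. A step of similar size back down in this assay is therefore expected. Compound 4 is estimated at 11000 nM, within a range of 4000 nM to 30000 nM. That estimate means a step of a 2.4-fold lower number from compound 3 to compound 4 (0.37 log units; beyond the scatter) is expected, modest and within reach of what the step from compound 1 to compound 3 showed.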

Compound 4, concentration for 50% growth inhibition: 5500 nM
Compound 4: middle estimate off by 2.0-fold (0.30 log units), on the high side; the measured number falls inside the stated range.
By their numbers in this assay, from the lowest: compounds 2, 4 and 1 (each within the scatter of the next, the first and the last beyond it); then compound 3.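

Within the data shown here, the change at this position in this assay gives a 4.7-fold lower number from compound 3 to compound 4 (0.67 log units; beyond the scatter) and leaves compound 3, the only compound here with benzyl(methyl)amino, apart from the other three. Within the (substituted benzyl)amino compounds, the ring can vary without a clear shift: methoxy in place of chloro gives a 2.0-fold lower number from compound 1 to compound 4 (0.30 log units; within the scatter) and 2-methoxyphenyl in place of 4-(tert-butyl)phenyl gives a 1.7-fold higher number from compound 2 to compound 4 (0.24 log units; within the scatter), both within the scatter. No measurement here explains why these numbers fall as they do.

As far as these compounds go, this step removes the methyl on the amine and adds a methoxy on the ring at once, so the share of each remains unknown. Plain benzylamino would help separate the two, and an ethyl group on that amine nitrogen would test whether the high number of compound 3 extends beyond methyl.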